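Ethoxycarbonyl in place of a ring hydrogen: working note

This account rests on a few compounds, and the source may have more. Where it says the series, first, only, none or still open, it means among the compounds named here.

Measured so far:
compound 1 `O=C(CO[N+](=O)[O-])NNC(=O)c1ccc(-n2[nH]c(=O)cc2-c2ccc([N+](=O)[O-])cc2)cc1` — 49.1 ug/mL
compound 2 `O=C(CO[N+](=O)[O-])NNC(=O)c1ccc(-n2[nH]c(=O)cc2-c2ccc(Cl)cc2)cc1` — 21.3 ug/mL

In a functional assay on aorta (Rattus norvegicus, strain Wistar) for inhibition (on this read-out higher numbers stand for an effect only at larger amounts of compound and lower numbers for an effect already at smaller amounts), compound 1 gives 49.1 ug/mL, the highest of the two numbers; compound 2 gives 21.3 ug/mL. Among the compounds with values here, the only measured step, a 2.3-fold lower number from compound 1 to compound 2 (0.36 log units; beyond the scatter), concerns the group on the phenyl ring, not the core carbon. Compound 3 `CCOC(=O)c1c(-c2ccc([N+](=O)[O-])cc2)n(-c2ccc(C(=O)NNC(=O)CO[N+](=O)[O-])cc2)[nH]c1=O` differs from compound 1 by ethoxycarbonyl in place of hydrogen on an aromatic carbon. Within the data shown here, no measured step touches this position, so the data give no direction for it; the one step on record elsewhere was modest. For compound 3 the number is therefore expected close to that of compound 1, a 1.2-fold lower number from compound 1 to compound 3 (0.09 log units; within the scatter), estimated at 40 ug/mL with a range of 15 ug/mL to 110 ug/mL.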

Compound 3, half-maximal effective concentration: 28.2 ug/mL
Compound 3: middle estimate off by 1.4-fold (0.15 log units), on the high side; the range from low to high includes it.
By their numbers in this assay, from the lowest: compounds 2, 3 and 1 (each within the scatter of the next, the first and the last beyond it).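

On an aromatic carbon of the five-membered ring, next to the ring atom that bears a 4-nitrophenyl group, ethoxycarbonyl replaces hydrogen in this assay with a 1.7-fold lower number from compound 1 to compound 3 (0.24 log units; within the scatter). Within the data shown here, this is the first reading at this position, and the change stays within the scatter, unlike the step on the phenyl ring substituent. Nothing available explains this outcome.

Open, on these data alone, is whether a carboxylic acid or an amine on the same carbon would also stay within the scatter. Also open, as far as these compounds go, is how ethoxycarbonyl reads with chloro in place of nitro.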